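The source may report more compounds than this note shows. Statements on the series, on what has been measured and on what is new or still open speak of the compounds shown alone.

Working notes on the series, read in an ADME assay on Vero cells (Chlorocebus sabaeus) for cytotoxicity; a higher number here means that more compound is tolerated, a lower number that less compound is tolerated. Compound 1 `CC(=O)c1c(Nc2ccc(F)cc2F)[nH]c2c(F)cc(F)cc2c1=O` carries 2,4-difluorophenyl on a nitrogen on an aromatic ring. In this assay compound 1 gives > 25000 nM, which is a limit of the assay and not a number. Compound 2 `CC(=O)c1c(NCc2ccc(F)cc2)[nH]c2c(F)cc(F)cc2c1=O`, with 4-fluorobenzyl in that place, gives > 25000 nM, which is also a limit. Compound 2 therefore has no exact number to start from. For the measured compounds named here, the only measured step is a step that the two limits leave unreadable from compound 1 to compound 2, so it supplies no size to carry forward. The whole record so far is the limit of > 25000 nM in this assay, at which 2 of the 2 values shown sit.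

Compound 3 `COc1cccc(Nc2[nH]c3c(F)cc(F)cc3c(=O)c2C(C)=O)c1` has 3-methoxyphenyl in place of 4-fluorobenzyl on a nitrogen on an aromatic ring. The step from compound 1 is the only one that bears on this change, and it shows no readable movement, so no change beyond the scatter is expected in this assay. The expected step is a number no higher from compound 2 to compound 3 (the limit leaves the size open). For compound 3 the estimated value is 25000 nM, with an expected range of 10000 nM to 50000 nM, and another limit is the likeliest report.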

Compound 3, half-maximal cytotoxic concentration: > 25000 nM
Compound 3 was reported as a limit (the forecaster's own chance of this, stated with the estimate: 75%); the middle value lies on the limit itself.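

No step among compound 1, compound 2 and compound 3 can be read, as all three are reported only at the same limit of the assay: the limit of > 25000 nM in this assay, at which 3 of the 3 values shown sit.

The compounds shown leave open whether exchanging the group on the nitrogen moves the half-maximal cytotoxic concentration at all in this assay, and where an exact value for any of the three would lie.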